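A few compounds are considered here, and "the series" means these few. Any claim that something is new, unique, unknown or untested is made for them only; others in the source may bear on it.

Of the compounds shown here, three on one shared core have been measured in a functional assay on MCF7 cells (Homo sapiens) for inhibition, read by MTT assay, with a stated time of 72 h (on this read-out lower numbers stand for stronger inhibition and higher numbers for weaker inhibition), and they differ only in the group on an aromatic nitrogen. Compound 1 (`Cc1cc2occ(-c3nc(-c4ccccc4)c(-c4ccccc4)n3-c3ccc([N+](=O)[O-])cc3)c(=O)c2cc1Cl`) reads 6250 nM there, compound 2 (`COc1ccccc1-n1c(-c2coc3cc(C)c(Cl)cc3c2=O)nc(-c2ccccc2)c1-c1ccccc1`) reads 25000 nM and compound 3 (`Cc1cc2occ(-c3nc(-c4ccccc4)c(-c4ccccc4)n3-c3ccccc3Cl)c(=O)c2cc1Cl`) reads 3120 nM on the same scale. Compound 3 therefore stands level with compound 1 and clear of compound 2. The measured gaps are a 2.0-fold lower number from compound 1 to compound 3 (0.30 log units; within the scatter) and an 8.0-fold lower number from compound 2 to compound 3 (0.90 log units; beyond the scatter) on this scale.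

Compound 4 (`Cc1ccc(-n2c(-c3coc4cc(C)c(Cl)cc4c3=O)nc(-c3ccccc3)c2-c2ccccc2)cc1`) brings a new group to that place: 4-methylphenyl in place of 2-chlorophenyl on an aromatic nitrogen. All three measured steps bear on this change, since each swaps the group at the same place, and the remaining one is a 4.0-fold higher number from compound 1 to compound 2 (0.60 log units; beyond the scatter) in size. Among the compounds with values here, no measured compound carries 4-methylphenyl, so no direct comparison exists. The nearest comparison is compound 1 (6250 nM), which carries 4-nitrophenyl. A small rise in this assay is therefore expected, one that stays within the scatter. The expected step is a 1.8-fold higher number from compound 3 to compound 4 (0.25 log units; within the scatter) by this estimate. For compound 4 the estimated value is 5500 nM and the expected range runs from 1800 nM to 18000 nM in this read-out.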

Compound 4, half-maximal inhibitory concentration: 12500 nM
Compound 4: middle estimate off by 2.3-fold (0.36 log units), on the low side, and the stated range covers the measured number.
By their numbers in this assay, from the lowest: compounds 3, 1, 4 and 2 (each within the scatter of the next, the first and the last beyond it).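

In this assay, the new group gives a 4.0-fold higher number from compound 3 to compound 4 (0.60 log units; beyond the scatter), so compound 3 now stands beyond the scatter from two of the three other groups on the aromatic nitrogen, although compound 1 still goes against any such separation. Compound 4 shows no gap beyond the scatter from either of its other neighbours, with a 2.0-fold higher number from compound 1 to compound 4 (0.30 log units; within the scatter) and a 2.0-fold lower number from compound 2 to compound 4 (0.30 log units; within the scatter). At this place, 4-methylphenyl and 4-nitrophenyl, which differ by methyl in place of nitro on an aromatic carbon, therefore cannot be told apart in this read-out, and 4-methylphenyl and 2-methoxyphenyl cannot be told apart either.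

Nothing at hand gives a reason for any of these steps. The compounds shown leave open whether the chloro group or its place on the ring sets compound 3 apart from compound 4, which 4-chlorophenyl and 2-methylphenyl on the same nitrogen would help to separate, and how this assay would respond to a phenyl ring carrying an amine or a carboxylic acid, or to a longer chain in place of the ring.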